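The source may hold more compounds than are shown below. What is called first, only, known or untested is meant among the compounds shown, and "the series" means these compounds.

Working notes on the series

The shared core carries a thiocarbamate-linked piperazine whose ring nitrogen bears the variable group. In a functional assay on MGC-803 cells (Homo sapiens) for antiproliferative activity, read by CCK-8 assay, with a stated time of 72 h, tested at 2 uM (a higher number here means a stronger effect of the compound at the concentration tested, a lower number a weaker effect), compound 1 `Nc1ccccc1NC(=O)c1ccc(CSC(=S)N2CCN(c3ccc(Cl)cc3)CC2)cc1` gives 15%, compound 2 `Nc1ccccc1NC(=O)c1ccc(CSC(=S)N2CCN(c3cccnc3)CC2)cc1` gives 27.6%, and compound 3 `Nc1ccccc1NC(=O)c1ccc(CSC(=S)N2CCN(Cc3ccncc3)CC2)cc1` gives 18.4%. Among the measured compounds shown here, compound 3 sits second highest of the three numbers, but the steps of a number 3.4 percentage points higher from compound 1 to compound 3 (within the scatter) and a number 9.2 percentage points lower from compound 2 to compound 3 (within the scatter) both stay within the scatter, so no order between compound 3 and either of the other two can be claimed; only the step of a number 12.6 percentage points higher from compound 1 to compound 2 (beyond the scatter) is beyond the scatter.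

Compound 4 `Nc1ccccc1NC(=O)c1ccc(CSC(=S)N2CCN(c3ccccc3F)CC2)cc1` differs from compound 3 by 2-fluorophenyl in place of (pyridin-4-yl)methyl on an amine nitrogen in a ring. For the measured compounds named here, the step that bears on it most closely is the one between compound 1 and compound 3, since compound 1 also carries a phenyl ring of carbon only directly on the ring nitrogen; that step, a number 3.4 percentage points higher from compound 1 to compound 3 (within the scatter), was within the scatter. Going by the values given here, the single step beyond the scatter, a number 12.6 percentage points higher from compound 1 to compound 2 (beyond the scatter), went toward the pyridin-3-yl group, which compound 4 does not carry. The expected step of a number 2.4 percentage points lower from compound 3 to compound 4 (within the scatter) in this assay is therefore none beyond the scatter, if anything slightly downward toward compound 1 because of 15%.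

Compound 4 is estimated at 16%, with a range from 6% to 28%.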

Compound 4, a percentage reported as inhibition, at one concentration (the size of the read-out at that concentration, not a potency): 33.7%
Compound 4: middle estimate off by 17.7 percentage points, on the low side; measured number above the stated range.
By their numbers in this assay, from the lowest: compounds 1, 3, 2 and 4 (each within the scatter of the next, the first and the last beyond it).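

The amine nitrogen in a ring tolerates a carbon-only aromatic group at the upper end of the series, and the two such groups are now separated: 2-fluorophenyl in place of 4-chlorophenyl gives a number 18.7 percentage points higher from compound 1 to compound 4 (beyond the scatter) in this assay, so a carbon-only aromatic ring on this nitrogen does not by itself keep the number low. Among the compounds shown here, the same group in place of (pyridin-4-yl)methyl gives a number 15.3 percentage points higher from compound 3 to compound 4 (beyond the scatter), the first step beyond the scatter that involves compound 3, while a number 6.1 percentage points higher from compound 2 to compound 4 (within the scatter) leaves 2-fluorophenyl and pyridin-3-yl without an order, so a ring nitrogen in the entering group is not needed to reach the level of compound 2. Nothing at hand accounts for these steps.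

The step from 4-chlorophenyl to 2-fluorophenyl changes both the halogen and its place on the ring, and the compounds shown do not separate the two. Unsubstituted phenyl, 4-fluorophenyl and 2-chlorophenyl would each bear on that question, and a 2-fluorobenzyl group would bear on the methylene link carried by compound 3.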